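The compounds below may be only part of what the source reports. "The series", "measured", "known", "first", "only" and "open" are said of these compounds alone.

Compound 1 `O=C(Nc1ccccc1)c1cnc(NCc2c(F)ccc3c2CCO3)n2cnnc12` has been tested in a physicochemical assay for solubility, read by LC-MS, in phosphate buffer, with a stated time of 24 h, at pH 7.4; on this read-out higher numbers stand for higher solubility and lower numbers for lower solubility. In this assay compound 1 gives < 1000 nM, which is a limit of the assay and not a number. Its solubility is therefore known only from one side.

Compound 4 `CN(c1ccn(C)n1)c1cnc(NCc2c(F)ccc3c2CCO3)n2cnnc12` has not yet been measured. It has methyl(1-methyl-1H-pyrazol-3-yl)amino in place of phenylcarbamoyl on an aromatic carbon of the core: methyl(1-methyl-1H-pyrazol-3-yl)amino in place of phenylcarbamoyl on an aromatic carbon.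

Going by the values given here, no measured step makes this exact change, so the nearest evidence is indirect. Compound 2 `Cc1nccn1-c1cnc(NCc2c(F)ccc3c2CCO3)c2cn[nH]c(=O)c12` gives 7000 nM and compound 3 `Cc1cc(-c2cnc(NCc3c(F)ccc4c3CCO4)c3cn[nH]c(=O)c23)n(C)n1` gives 1000 nM. Both carry a five-membered aromatic ring, as the entering group does, but their core differs from that of compound 1. Exchanging one such ring for another gave a 7.0-fold lower number from compound 2 to compound 3 (0.85 log units; beyond the scatter), so the choice of ring alone can shift the number by a modest amount.

On the values of compound 2 and compound 3, a modest upward step is expected, estimated as an at least 2.5-fold higher number from compound 1 to compound 4 (0.39 log units; beyond the scatter). Its size is uncertain, as the starting point is only a limit.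

For compound 4 the expected value is 2500 nM, with an estimated range from 600 nM to 10000 nM.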

Compound 4, solubility: 130000 nM
Compound 4: the middle estimate sits 52-fold (1.72 log units) below what was measured; measured number above the stated range.
By their numbers in this assay, from the lowest: compound 3; then compound 2; then compound 4.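

On the core of compound 1, the group on this aromatic carbon, para to a large group, can alone move the number a long way in this assay: methyl(1-methyl-1H-pyrazol-3-yl)amino in place of phenylcarbamoyl gives an at least 130-fold higher number from compound 1 to compound 4 (2.11 log units; beyond the scatter). Going by these compounds alone, the only earlier step, a 7.0-fold lower number from compound 2 to compound 3 (0.85 log units; beyond the scatter), was modest, came from a different core and swapped one five-membered aromatic ring for another, so it said nothing about removing phenylcarbamoyl here. The size of the new step is a minimum, not an exact figure, as compound 1 is known only through a limit: the limit of < 1000 nM in this assay, at which 1 of the 4 values shown sits.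

In this change the phenyl ring, the carbonyl and the pyrazole ring all change at once, so the compounds shown cannot say which part matters. A simple methylamino or phenylamino group at this position on the same core would begin to separate these parts.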